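The source may report more compounds than this note shows. Statements on the series, on what has been measured and on what is new or still open speak of the compounds shown alone.

Measured so far:
compound 1 `c1ccc(-c2cn3ccnc3c(-c3ccc4ncn(C5CCCCC5)c4c3)n2)cc1`, 28.7%
compound 2 `COc1ccc(-c2cn3ccnc3c(-c3ccc4ncn(C5CCCCC5)c4c3)n2)cc1`, -18.6%
compound 3 `O=Cc1ccc(-c2cn3ccnc3c(-c3ccc4ncn(C5CCCCC5)c4c3)n2)cc1`, 13%

In a functional assay on MDA-MB-435 cells (Homo sapiens) for inhibition, read by sulforhodamine B assay, with a stated time of 48 h, tested at 10 uM (on this read-out lower numbers stand for less inhibition and higher numbers for more inhibition at the one concentration tested (going by the name of the read-out)), compound 3 stands second highest of the three, with a number 15.7 percentage points lower from compound 1 to compound 3 (beyond the scatter) and a number 31.6 percentage points higher from compound 2 to compound 3 (beyond the scatter). Compound 4 `Fc1ccc(-c2cn3ccnc3c(-c3ccc4ncn(C5CCCCC5)c4c3)n2)cc1` differs from compound 3 in one place: fluoro in place of formyl on an aromatic carbon. For the measured compounds named here, no measured step involves fluoro, so the bearing steps are indirect: a number 47.3 percentage points lower from compound 1 to compound 2 (beyond the scatter) and a number 15.7 percentage points lower from compound 1 to compound 3 (beyond the scatter) show that either group put onto the unsubstituted ring of compound 1 lowered the read-out. Fluoro is a single heavy atom with no acceptor, and it is expected to leave the number near that of compound 3 or compound 1, so a number 2 percentage points higher from compound 3 to compound 4 (within the scatter) is the expected step, within or barely beyond the scatter. Compound 4 is estimated at 15%, range -15% to 40%.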

Compound 4, a percentage reported as inhibition, at one concentration (the size of the read-out at that concentration, not a potency): 1.78%
For compound 4 the middle estimate is 13.2 percentage points above the measured one; measured number inside the range.
By their numbers in this assay, from the lowest: compound 2; then compound 4; then compound 3; then compound 1.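

In this assay the change to fluoro gives a number 26.9 percentage points lower from compound 1 to compound 4 (beyond the scatter) and so joins methoxy and formyl: all three groups, para to a large group, lower the number relative to the unsubstituted ring of compound 1. Heavy-atom count does not set the order, with a number 11.2 percentage points lower from compound 3 to compound 4 (beyond the scatter) on replacing formyl by fluoro and a number 20.4 percentage points higher from compound 2 to compound 4 (beyond the scatter) on replacing methoxy by fluoro. Nothing available explains this order.

Open, on these data alone, is whether an amine or a carboxylic acid at this place would match or exceed the unsubstituted ring of compound 1.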